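Sulfoxide-to-sulfone step at the ketone side chain

The compounds below may be only part of what the source reports. "The series", "measured", "known", "first", "only" and "open" are said of these compounds alone.

Compound 1 `CCCCc1nc(SC)c(C(=O)C[S+](C)[O-])n1Cc1ccc(-c2ccccc2S(=O)(=O)NC(=O)NCc2ccccc2)cc1` is measured in a functional assay on the whole organism for inhibition, with Rattus norvegicus as the target (a lower number here means that less compound is needed, a higher number that more compound is needed for the effect), at 0.7 mg/kg, and sits at the low end of the three numbers, with compound 2 `CCCc1nc(SC)c(C(=O)C[S+]([O-])c2ccccc2)n1Cc1ccc(-c2ccccc2S(=O)(=O)NC(=O)NCc2ccccc2)cc1` at 0.8 mg/kg and compound 3 `CCCc1nc(SC)c(C(=O)C[S+]([O-])c2ccccc2)n1Cc1ccc(-c2ccccc2S(=O)(=O)NC(=O)NCc2cccs2)cc1` at 1.4 mg/kg both within the usual scatter of it. Within the data shown here, the only single-point step measured, a 1.8-fold higher number from compound 2 to compound 3 (0.24 log units; within the scatter), lies at the benzylic end of the urea and does not touch the place changed here. Compound 4 `CCCCc1nc(SC)c(C(=O)CS(C)(=O)=O)n1Cc1ccc(-c2ccccc2S(=O)(=O)NC(=O)NCc2ccccc2)cc1` differs from compound 1 by a group of 4 heavy atoms (1 carbon, 2 oxygen, 1 sulfur; no ring) in place of a group of 3 heavy atoms (1 carbon, 1 oxygen, 1 sulfur; no ring), on a saturated chain carbon bound to a carbonyl carbon. Among the measured compounds shown here, no measured step bears on this change, so no shift beyond the scatter is expected in this assay. Compound 4 is therefore estimated at 0.8 mg/kg, with a range of 0.35 mg/kg to 1.8 mg/kg, which means an expected step of a 1.1-fold higher number from compound 1 to compound 4 (0.06 log units; within the scatter).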

Compound 4, dose for 50% inhibition: 1.7 mg/kg
Beside the measured number, compound 4's estimate is 2.1-fold (0.33 log units) below it, and the stated range covers the measured number.
By their numbers in this assay, from the lowest: compounds 1, 2, 3 and 4 (each within the scatter of the next, the first and the last beyond it).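

At this saturated chain carbon bound to a carbonyl carbon, methylsulfonyl in place of the sulfoxide group gives a 2.4-fold higher number from compound 1 to compound 4 (0.39 log units; beyond the scatter) in this assay. Among these compounds, this position therefore responds to the change at sulfur, though modestly, whereas the one earlier step, at the urea end, stays within the scatter. No available data bear on the reason for this step. On these data alone, whether the same change holds with the phenyl sulfoxide of compound 2 remains open. As far as these compounds go, how a thioether or a carboxylic acid at this place would read in this assay is also open.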